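Carboxy for Sulfamoyl: Clearance of Compound 4

A few compounds are considered here, and "the series" means these few. Any claim that something is new, unique, unknown or untested is made for them only; others in the source may bear on it.

compound 1 `COc1ccc(-c2cc(-c3ccc(S(N)(=O)=O)cc3)cnc2N)cn1` — < 7 mL.min-1.g-1
compound 2 `COc1ccc(-c2cnc(N)c(-c3ccc(OC)nc3)c2)cn1` — 19.9 mL.min-1.g-1
compound 3 `COc1ccc(-c2cc(-c3ccc4nccn4c3)cnc2N)cn1` — 12 mL.min-1.g-1

In an in vitro ADME assay on microsomes from liver (Homo sapiens) for metabolic stability (a higher number here means faster removal of the compound, a lower number slower removal), compound 1 gives < 7 mL.min-1.g-1, which is a limit of the assay and not a number. Compound 1 is the one of the three measured compounds that sits at the limit of < 7 mL.min-1.g-1 in this assay, at which 1 of the 3 values shown sits. Compound 2 gives 19.9 mL.min-1.g-1 in this assay, and compound 3 gives 12 mL.min-1.g-1; both of these are numbers, not limits, and both lie on the faster side of where compound 1 stands.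

Compound 4 `COc1ccc(-c2cc(-c3ccc(C(=O)O)cc3)cnc2N)cn1` differs from compound 1 in one place: carboxy in place of sulfamoyl on an aromatic carbon, para to a large group. Going by the values given here, no pair of measured compounds shows a change of this kind, so the size of the step cannot be read from the data; the expectation is a step within the usual scatter of this assay, with no direction beyond it. Compound 4 is therefore expected to give about 6 mL.min-1.g-1, in a range from 3 mL.min-1.g-1 to 12 mL.min-1.g-1. The expected step that the limit leaves unreadable from compound 1 to compound 4 is estimated to stay within the scatter, and the assay may well report only a limit again for compound 4.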

Compound 4, intrinsic clearance in microsomes: < 7 mL.min-1.g-1
Compound 4: no number, only a limit; the forecaster's own chance of this, stated with the estimate: 60%; the middle value lies beyond the limit too.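

No step can be read from compound 1 to compound 4 in this assay, because each of the two compounds gives a limit of the assay and not a number: the limit of < 7 mL.min-1.g-1 in this assay, at which 2 of the 4 values shown sit.

The compounds shown leave open whether carboxy in place of sulfamoyl changes intrinsic clearance in microsomes at all, and by how much.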